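The source may hold more compounds than are shown below. What is called first, only, known or untested is meant among the compounds shown, and "the series" means these compounds.

Measured compounds in a functional assay on ECa-109 cells (Homo sapiens) for inhibition, read by MTT assay, with a stated time of 72 h; on this read-out higher numbers stand for weaker inhibition and lower numbers for stronger inhibition:

compound 1 `C#CCSc1nc(Nc2ccc(OC)cc2)c(C#N)c(-c2ccccc2)n1` gives 23200 nM
compound 2 `N#Cc1c(Nc2cccc(C(F)(F)F)c2)nc(SCc2cn(Cc3ccccc3Cl)nn2)nc1-c1ccccc1` gives 32000 nM
compound 3 `N#Cc1c(Nc2ccccc2Cl)nc(SCc2cn(Cc3ccccc3Cl)nn2)nc1-c1ccccc1` gives 28500 nM

Compound 2 carries the highest of the three numbers, yet it is not set apart: the step of a 1.1-fold lower number from compound 2 to compound 3 (0.05 log units; within the scatter) is within the scatter, and the value of compound 1 is also within the scatter of compound 2. Across these three, all readings fall in one band.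

The next compound, compound 4 `N#Cc1c(Nc2ccccc2)nc(SCc2cn(Cc3ccccc3Cl)nn2)nc1-c1ccccc1`, is not yet measured. Relative to compound 2 the change is hydrogen in place of trifluoromethyl on an aromatic carbon, leaving the rest of the molecule untouched; read one bond further out it is 3-(trifluoromethyl)phenyl to phenyl.

Among the measured compounds shown here, only one measured step touches the same position of the molecule: from compound 2 to compound 3 the 3-(trifluoromethyl)phenyl was swapped for 2-chlorophenyl, and that step, a 1.1-fold lower number from compound 2 to compound 3 (0.05 log units; within the scatter), stayed within the scatter. For the measured compounds named here, removing the trifluoromethyl altogether is a smaller edit of the same ring, and there is no step showing that a group on this anilino ring shifts the read-out beyond the scatter. The expected step from compound 2 to compound 4 in this assay is therefore a 1.1-fold lower number from compound 2 to compound 4 (0.03 log units; within the scatter), with no direction beyond the scatter.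

Compound 4 is accordingly estimated at 30000 nM, between 13000 nM and 70000 nM.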

Compound 4, half-maximal inhibitory concentration: > 64000 nM
Compound 4 ended at the assay's limit (the forecaster's own chance of this, stated with the estimate: 10%); at least 2.1-fold (0.32 log units) between middle value and limit.
By their numbers in this assay, from the lowest: compounds 1, 3 and 2 (each within the scatter of the next). At a limit, above all of these: compound 4.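

In this assay compound 4, which carries the unsubstituted anilino ring, gives > 64000 nM, and this is a limit of the assay rather than a number. Among the compounds shown here, the position now shows that it can matter: hydrogen in place of chloro gives an at least 2.2-fold higher number from compound 3 to compound 4 (0.35 log units; beyond the scatter), the only step on this ring that clearly moves the read-out, while hydrogen in place of trifluoromethyl gives an at least 2.0-fold higher number from compound 2 to compound 4 (0.30 log units; that floor lies within the scatter), so its floor alone does not separate the two compounds. The swap between the two substituted rings stayed within the scatter, and the bare ring now sits apart from at least one of them, though the real size of both new steps cannot be read from this value: the limit of > 64000 nM in this assay, at which 1 of the 4 values shown sits.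

On these data alone, whether any group on this ring would hold the read-out, or only groups like chloro and trifluoromethyl, remains open, as an amine, a carboxylic acid or a simple methyl on the same ring could read with either side. Compound 1 carries a methoxy on this ring but differs elsewhere too, so it does not settle the question.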